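The source may report more compounds than this note shows. Statements on the series, on what has been measured and on what is new or still open speak of the compounds shown alone.

Measured compounds:
Compound 1 `CSc1nn(-c2ccccc2)c2ncnc(N/N=C/c3cccc(O)c3)c12` gives 10.7 nM in a functional assay on MCF7 cells (Homo sapiens) for inhibition, read by sulforhodamine B assay, with a stated time of 48 h; on this read-out lower numbers stand for stronger inhibition and higher numbers for weaker inhibition.
Compound 2 `COc1ccc(-n2nc(SC)c3c(N/N=C/c4ccc(F)cc4)ncnc32)cc1` gives 12.1 nM in this assay.
Compound 3 `COc1ccc(-n2nc(SC)c3c(N/N=C/c4ccccc4O)ncnc32)cc1` gives 13.3 nM in this assay.

Compound 3 holds the highest of the three numbers, but its nearest neighbour compound 2 and its furthest neighbour compound 1 both lie within the scatter of it, so no order can be read among them. The unmeasured compound 4 `COc1ccc(-n2nc(SC)c3c(N/N=C/c4cccc(O)c4)ncnc32)cc1` differs from compound 3 in one place: 3-hydroxyphenyl in place of 2-hydroxyphenyl on a carbon with a double bond to nitrogen. Within the data shown here, the only measured step at that same place is a 1.1-fold higher number from compound 2 to compound 3 (0.04 log units; within the scatter), which did not move the number beyond the scatter. Among the measured compounds shown here, compound 1, which also carries a 3-hydroxyphenyl at this position but a different group on the core, shows a value close to that of compound 3, though no single step links those two. The data therefore give no ground to expect a change beyond the scatter. For compound 4 the estimate is 11.5 nM, with a range from 5 nM to 26 nM, which is expected to amount to a 1.2-fold lower number from compound 3 to compound 4 (0.06 log units; within the scatter).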

Compound 4, half-maximal inhibitory concentration: 9.9 nM
Beside the measured number, compound 4's estimate is 1.2-fold (0.07 log units) above it, within the range that was stated.
By their numbers in this assay, from the lowest: compounds 4, 1, 2 and 3 (each within the scatter of the next).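

In this assay, at the carbon with a double bond to nitrogen, neither 3-hydroxyphenyl in place of 2-hydroxyphenyl (a 1.3-fold lower number from compound 3 to compound 4 (0.13 log units; within the scatter)) nor 3-hydroxyphenyl in place of 4-fluorophenyl (a 1.2-fold lower number from compound 2 to compound 4 (0.09 log units; within the scatter)) leaves the scatter, so on this shared core the three groups cannot be told apart. With 3-hydroxyphenyl held fixed, methoxy in place of hydrogen on an aromatic carbon (a 1.1-fold lower number from compound 1 to compound 4 (0.03 log units; within the scatter)) also stays within the scatter, so this second place shows no separable contribution either. Nothing available bears on why these numbers lie so close together.

All the groups shown at the first place are substituted phenyl rings, so it remains open whether an amine or a carboxylic acid there would move the number beyond the scatter. From the compounds shown here alone, whether a longer chain such as butoxy in place of the methoxy would do so also remains open.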